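Aromatic hydroxy to amino on the methoxyphenyl arm

This account rests on a few compounds, and the source may have more. Where it says the series, first, only, none or still open, it means among the compounds named here.

compound 1 `COc1ccc(CN(C(=O)CSc2nc3ccccc3s2)c2cc(OC)c(OC)c(OC)c2)cc1O`: 35 nM
compound 2 `COc1ccc(CN(C(=O)CSc2nc3cc(Cl)ccc3s2)c2cc(OC)c(OC)c(OC)c2)cc1O`: 85 nM

In a functional assay on MGC-803 cells (Homo sapiens) for antiproliferative activity, read by MTT assay, with a stated time of 48 h (on this read-out higher numbers stand for weaker inhibition and lower numbers for stronger inhibition), compound 1 gives 35 nM, the lowest of the two numbers in hand. The nearest is compound 2, which gives 85 nM. The step of a 2.4-fold higher number from compound 1 to compound 2 (0.39 log units; beyond the scatter) comes from chloro in place of hydrogen on an aromatic carbon of the shared core.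

Compound 3, `COc1ccc(CN(C(=O)CSc2nc3ccccc3s2)c2cc(OC)c(OC)c(OC)c2)cc1N`, is not yet measured. It differs from compound 1 in one place: amino in place of hydroxy on an aromatic carbon. Going by the values given here, no measured step bears on this change; the only step in hand concerns a chloro on the core, not the hydroxy group. The leaving and entering groups match in size and in what is counted, so the step expected from compound 1 to compound 3, a 1.2-fold lower number from compound 1 to compound 3 (0.07 log units; within the scatter), is small, within the usual scatter, with no firm direction. For compound 3 the estimate in this assay is 30 nM, with a range from 10 nM to 100 nM.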

Compound 3, half-maximal inhibitory concentration: 84 nM
Estimate against measurement, compound 3: 2.8-fold (0.45 log units) below; the measured number falls inside the stated range.
By their numbers in this assay, from the lowest: compound 1; then compounds 3 and 2 (each within the scatter of the next).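

In this assay, going by these compounds alone, changing the 3-hydroxy-4-methoxyphenyl arm to the 3-amino-4-methoxyphenyl arm gives a 2.4-fold higher number from compound 1 to compound 3 (0.38 log units; beyond the scatter), the first measured step on this arm, as the earlier step lay on the shared core. The place ortho to a methoxy group therefore responds to this exchange, modestly but beyond the scatter, even though hydroxy and amino match in heavy atoms, hydrogen-bond donors and acceptors. Nothing in hand explains the step.

The compounds shown do not tell whether a fluoro, methoxy or methylamino group at this place would stand closer to hydroxy or to amino. They also leave open whether the amino arm and the chloro on the core would combine in a single compound, and how such a compound would read.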